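Compound 3: hydrogen in place of methyl

This account rests on a few compounds, and the source may have more. Where it says the series, first, only, none or still open, it means among the compounds named here.

Going by the values given here, in a physicochemical assay for metabolic stability, read by LC-MS, with a stated time of 38 days, tested at 10 mM (a higher number here means that more of the compound is left, a lower number that less of the compound is left), two compounds carry numbers so far. Compound 2 (`Cc1ccc(-c2cc(C(=O)O)ccn2)o1`) stands highest of the two at 85% for now. Compound 1 (`Cc1ccc(-c2cc(C(=O)Nc3nnc(-c4ccncc4)s3)ccn2)o1`) reads 34% and so lies under compound 2 by a gap beyond the usual scatter.

The next compound to be read is compound 3 (`O=C(O)c1ccnc(-c2ccco2)c1`). It departs from compound 2 by a single change (hydrogen in place of methyl on an aromatic carbon), hydrogen in place of methyl on an aromatic carbon. Among the compounds with values here, no two measured compounds differ in one place only, so the data hold no measured size for a step of this kind.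

The expectation therefore rests on the small size of the change and on the room left above compound 2 at 85% in this series. The estimated step is a number 1 percentage points higher from compound 2 to compound 3 (within the scatter) and it is expected to stay within the scatter, with no firm direction. For compound 3 the expected value in this assay is 86%, with an estimated range of 71% to 98% for the reading still to come.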

Compound 3, percent of the compound remaining: 92%
Estimate against measurement, compound 3: 6 percentage points below, within the range that was stated.
By their numbers in this assay, from the lowest: compound 1; then compounds 2 and 3 (each within the scatter of the next).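

Methyl next to the ring oxygen of the five-membered aromatic ring now has a measured step: in this assay, hydrogen in place of methyl gives a number 7 percentage points higher from compound 2 to compound 3 (within the scatter). On this pair, the methyl can therefore leave this place without a reading that stands apart from the scatter, so the methyl is not required to keep the percent of compound remaining in the range of compound 2; this is one step on one pair, and it gives no direction for the position. No measured evidence on the cause of this reading accompanies the step.

The compounds shown leave open whether an ethyl chain, a methoxy group or an amine at this same place, two ring bonds from the ring atom that bears the group of 9 heavy atoms, would also stay within the scatter of compound 3. As far as these compounds go, it also remains open whether hydrogen in place of methyl on the core of compound 1, which carries an amide in place of the carboxylic acid, would give a step of similar size in this assay.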